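The source may hold more compounds than are shown below. What is called first, only, known or untested is meant among the compounds shown, and "the series" means these compounds.

In an ADME assay on microsomes from liver (Homo sapiens) for metabolic stability, read by LC-MS, with NADPH named in the record, with a stated time of 60 min, tested at 1 uM, in the absence of a further agent (on this read-out lower numbers stand for a less stable compound and higher numbers for a more stable compound), compound 1 `COc1ccc(-c2c(C)nc3c(N4CC[C@@H](NC(C)=O)C4)cc(C)nn23)cc1OC` gives > 95%, which is a limit of the assay and not a number. Compound 2 `CC(=O)N[C@@H]1CCN(c2cc(C)nn3c(-c4ccc(C#N)cc4)c(C)nc23)C1` gives > 95%, also a limit. Among the compounds with values here, the only measured step is a step that the two limits leave unreadable from compound 1 to compound 2, with 4-cyanophenyl in place of 3,4-dimethoxyphenyl on an aromatic carbon. It has no readable size and concerns a different group, so it offers little guidance here. The record so far is summed up by the limit of > 95% in this assay, at which 2 of the 2 values shown sit. Compound 3 `COc1ccc(-c2c(C)nc3c(N4CC[C@@H](NC(C)=O)C4)cc(Cl)nn23)cc1OC` carries chloro in place of methyl on an aromatic carbon of the core of compound 1: chloro in place of methyl on an aromatic carbon. Within the data shown here, no measured step covers this exchange, so the expectation is loose: no change beyond the scatter, or a modest fall in this assay. Compound 3 is estimated at 90%, with an expected range of 72% to 100%. The expected change is a number at least 5 percentage points lower from compound 1 to compound 3 (that floor lies within the scatter).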

Compound 3, percent of the compound remaining: > 95%
Compound 3: no number, only a limit; the forecaster's own chance of this, stated with the estimate: 50%; at least 5 percentage points between middle value and limit.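

Compound 1 and compound 3 both stand only at a limit in this assay, and no step can be read between them. The compounds shown leave open whether chloro in place of methyl changes the percent of compound remaining, and the record stays at one mark: the limit of > 95% in this assay, at which 3 of the 3 values shown sit.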